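Pyrazine hydrazone series: cytotoxicity on J774 cells

The source may report more compounds than this note shows. Statements on the series, on what has been measured and on what is new or still open speak of the compounds shown alone.

Measured so far:
- compound 1 `O=C(N/N=C/c1ccccc1)c1cnccn1`: 100%
- compound 2 `O=C(N/N=C/c1ccccc1Cl)c1cnccn1`: 70%
- compound 3 `O=C(N/N=C/c1ccc(F)cc1)c1cnccn1`: 78%

In an ADME assay on J774 cells (Mus musculus) for cytotoxicity, read by MTT assay, with a stated time of 48 h, tested at 50 ug/mL (a lower number here means a stronger effect, a higher number a weaker effect of the compound at the concentration tested), compound 1 gives 100%, the highest of the three numbers; its nearest neighbour is compound 3 at 78%, and compound 2 at 70% lies furthest away, both gaps beyond the scatter.

Compound 4 `N#Cc1cccc(/C=N/NC(=O)c2cnccn2)c1` is not yet measured. It differs from compound 1 in one place: cyano in place of hydrogen on an aromatic carbon. The entering group is cyano, two heavy atoms with one triple bond outside aromatic rings, on an aromatic carbon of a six-membered aromatic ring of carbon only.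

Among the measured compounds shown here, two measured steps bear on this change, both swapping a ring hydrogen for a halogen: a number 30 percentage points lower from compound 1 to compound 2 (beyond the scatter) and a number 22 percentage points lower from compound 1 to compound 3 (beyond the scatter). Both lowered the number by a modest amount beyond the scatter. A third substituent of a different kind at a different place on that ring is therefore expected to lower the number in this assay by a modest amount as well, though the size is uncertain with only two prior substitutions as a guide.

For compound 4 the estimate in this assay is 80%, with a range from 60% to 100%. This estimate means an expected step of a number 20 percentage points lower from compound 1 to compound 4 (beyond the scatter).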

Compound 4, a percentage reported as activity, at one concentration (the size of the read-out at that concentration, not a potency): 100%
Beside the measured number, compound 4's estimate is 20 percentage points below it; the range from low to high includes it.
By their numbers in this assay, from the lowest: compounds 2 and 3 (each within the scatter of the next); then compounds 1 and 4 (each within the scatter of the next).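

In this assay cyano in place of hydrogen, meta to a large group on the aromatic ring, gives no change at the digits printed from compound 1 to compound 4 (within the scatter) and so shows that a new group on this ring need not lower the number. The halogen steps a number 30 percentage points lower from compound 1 to compound 2 (beyond the scatter) and a number 22 percentage points lower from compound 1 to compound 3 (beyond the scatter) therefore hold for chloro and fluoro in their own places but give no rule for the whole ring, and compound 4 goes against any such rule. Nothing at hand explains why cyano differs from these two halogens.

Whether the difference follows the group or its place stays open, as chloro or fluoro meta to a large group is not among the compounds shown. Also open, going by these compounds, is whether an amine or a carboxylic acid in that place would leave the number where it stands or lower it.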